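A Fluorine for a Hydroxyl on the Sulfonyl Phenyl

The compounds below may be only part of what the source reports. "The series", "measured", "known", "first", "only" and "open" are said of these compounds alone.

Of the compounds shown here, three have been tested in an ADME assay on HEK293 cells (Homo sapiens) for cytotoxicity, read by resazurin assay, with a stated time of 48 h; a lower number here means that less compound is tolerated, a higher number that more compound is tolerated. Compound 1 `O=S(=O)(Nc1ccc2oc(-c3ccccc3)nc2c1)c1ccc(Cl)c(C(F)(F)F)c1` gives 66000 nM, and compound 2 `CCc1ccc(S(=O)(=O)Nc2ccc(-c3nc4ccccc4o3)cc2)cc1` gives 82000 nM. These two values lie within the usual scatter of each other, so neither stands apart from the other. Compound 3 `O=S(=O)(Nc1ccc2oc(-c3ccccc3)nc2c1)c1ccc(O)cc1` returns only a limit in this assay, > 100000 nM, which means the assay reported no number for it. This is the limit described as the limit of > 100000 nM in this assay, at which 1 of the 3 values shown sits. On the numbers shown, compound 3 therefore sits at the tolerated end of the series, with no exact number to place it further.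

Compound 4 `O=S(=O)(Nc1ccc2oc(-c3ccccc3)nc2c1)c1ccccc1F` has not yet been measured. It differs from compound 3 in one place: 2-fluorophenyl in place of 4-hydroxyphenyl on a sulfonyl sulfur. No change of this kind has been measured here between two compounds with numbers, so its effect on cytotoxicity is open. The two compounds with numbers, compound 1 and compound 2, sit close to the limit, and compound 3 sits at it, so any step in this assay from compound 3 to compound 4 is expected to be small, likely no larger than the scatter, and may again end at the limit. Compound 4 is estimated at 80000 nM, within 40000 nM to 150000 nM, and that estimate means a step of an at least 1.2-fold lower number from compound 3 to compound 4 (0.09 log units; that floor lies within the scatter).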

Compound 4, half-maximal cytotoxic concentration: 72000 nM
Estimate against measurement, compound 4: 1.1-fold (0.05 log units) above, within the range that was stated.
By their numbers in this assay, from the lowest: compounds 1, 4 and 2 (each within the scatter of the next). At a limit, above all of these: compound 3.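

In this assay putting 2-fluorophenyl in place of 4-hydroxyphenyl on a sulfonyl sulfur gives an at least 1.3-fold lower number from compound 3 to compound 4 (0.14 log units; that floor lies within the scatter) and this figure is only a floor, so the true size of the step cannot be read and it may be larger. Within the data shown here, compound 3 remains a limit rather than a number, and it is the only compound that does: the limit of > 100000 nM in this assay, at which 1 of the 4 values shown sits. With this change the series gains a second measured compound on the same core, since compound 4 now has a number that lies within the scatter of compound 1, which differs from it only in the group on the sulfonyl sulfur.

One change at this position cannot separate what the incoming fluorine contributes from what the departing hydroxyl contributes, and it cannot show whether the place of the fluorine on the ring matters. As far as these compounds go, how an unsubstituted phenyl, or a phenyl carrying an amine or a carboxylic acid, would stand on this sulfonyl sulfur also stays open, and such a comparison would show whether cell tolerance shifts at all with the group here.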